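Methyl ester to free acid in the sulfone series

The source may report more compounds than this note shows. Statements on the series, on what has been measured and on what is new or still open speak of the compounds shown alone.

Values in a functional assay on DU-145 cells (Homo sapiens) for cytotoxicity, read by trypan blue exclusion, with a stated time of 96 h (a lower number here means a stronger inhibitor, a higher number a weaker inhibitor), follow.
- compound 1 `COc1ccc(CS(=O)(=O)/C=C/c2c(OC)cccc2OC)c([N+](=O)[O-])c1` gives 50000 nM
- compound 2 `COc1cc(OC)c(/C=C/SCc2ccc(OC)c(N)c2)c(OC)c1` gives 50 nM
- compound 3 `COC(=O)C(C)(C)Nc1cc(CS(=O)(=O)/C=C/c2c(OC)cc(OC)cc2OC)ccc1OC` gives 2500 nM

Compound 3 (2500 nM) stands second highest of the three numbers, beyond the scatter from both others. Compound 4 `COc1cc(OC)c(/C=C/S(=O)(=O)Cc2ccc(OC)c(NC(C)(C)C(=O)O)c2)c(OC)c1` is not yet measured. It differs from compound 3 (hydrogen in place of methyl on an oxygen next to a carbonyl group) by hydrogen in place of methyl on an oxygen next to a carbonyl group, which reads methoxycarbonyl to carboxy. Within the data shown here, no measured pair shows this change alone, so its size is uncertain. Compound 2 (50 nM) shows that much lower numbers occur in this assay, so a moderate move to a lower number, beyond the scatter, is expected. The expected change is a 5.0-fold lower number from compound 3 to compound 4 (0.70 log units; beyond the scatter) (an estimate only). The estimated value for compound 4 is 500 nM (expected range 60 nM to 4000 nM).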

Compound 4, half-maximal inhibitory concentration: 150 nM
For compound 4 the middle estimate is 3.3-fold (0.52 log units) above the measured one; the measured number falls inside the stated range.
By their numbers in this assay, from the lowest: compound 2; then compound 4; then compound 3; then compound 1.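

Methoxycarbonyl to carboxy gives the first single-place step in the series: in this assay there is a 17-fold lower number from compound 3 to compound 4 (1.22 log units; beyond the scatter). The methyl on the oxygen next to the carbonyl group is therefore not needed for a low number in the sulfone series, and this position responds strongly to a change of one heavy atom. Nothing measured here accounts for the size of the step.

On these data alone, an amide formed at the same carbonyl, or a longer chain carrying the carboxy group, remains open. So does whether a hydroxyethyl group could replace the carboxy-bearing chain.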